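The source may hold more compounds than are shown below. What is called first, only, known or untested is meant among the compounds shown, and "the series" means these compounds.

For the measured compounds named here, compound 2, whose structure is `CNC(=O)NC[C@H]1O[C@@H](n2cnc3c(NC(=O)Nc4ccccc4)ncnc32)[C@H](O[Si](C)(C)C(C)(C)C)[C@@H]1CC(=O)N(C)OC`, shows the lower of the two numbers measured so far in a functional assay on RPMI8266 cells (Homo sapiens) for antiproliferative activity (on this read-out lower numbers stand for stronger inhibition of growth and higher numbers for weaker inhibition of growth), giving 1.58 nM. Going by the values given here, the only other measured compound is compound 1, with the structure `CCOC(=O)C[C@H]1[C@@H](O[Si](C)(C)C(C)(C)C)[C@H](n2cnc3c(NC(=O)Nc4ccccc4)ncnc32)O[C@@H]1COC(=O)NC`, which in this assay gives 2.16 nM; the gap between the two lies within the usual scatter, so neither can be called stronger than the other.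

Compound 3, with the structure `CCOC(=O)C[C@H]1[C@@H](O[Si](C)(C)C(C)(C)C)[C@H](n2cnc3c(NC(=O)Nc4ccccc4)ncnc32)O[C@@H]1CNC(=O)NC`, has not yet been measured. It differs from compound 2 in a single place: ethoxy in place of methoxy(methyl)amino on a carbonyl carbon.

Among the compounds with values here, since no pair of measured compounds differing in one place is available, the size of this step is not known from direct comparison. Compound 1 carries the same ethoxy group on its carbonyl carbon and gives 2.16 nM, which lies within the scatter of compound 2, so a step no larger than the scatter is expected here. The expected step from compound 2 to compound 3 is a 1.3-fold higher number from compound 2 to compound 3 (0.10 log units; within the scatter). For compound 3 the estimated value in this assay is 2 nM, with a likely range from 0.9 nM to 4.5 nM.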

Compound 3, concentration for 50% growth inhibition: 1.09 nM
The estimate for compound 3 lay 1.8-fold (0.26 log units) above the measured number, within the range that was stated.
By their numbers in this assay, from the lowest: compounds 3, 2 and 1 (each within the scatter of the next).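

Swapping methoxy(methyl)amino for ethoxy on a carbonyl carbon can now be read directly in this assay: the change gives a 1.4-fold lower number from compound 2 to compound 3 (0.16 log units; within the scatter), so on these numbers the two groups cannot be told apart at this position. A first direct reading also appears at a second place, the saturated chain carbon bound to a saturated ring carbon, where (methylcarbamoyl)amino in place of (methylcarbamoyl)oxy gives a 2.0-fold lower number from compound 1 to compound 3 (0.30 log units; within the scatter), and this change likewise cannot be told apart from repeat-to-repeat variation. Nothing at hand offers an explanation for how little either change moves the number.

The compounds shown do not tell how a free carboxylic acid or a longer chain would behave on the carbonyl carbon, since ethoxy and methoxy(methyl)amino are the only two groups compared there. They also do not tell whether a plain amine on the saturated chain carbon would fit the same picture as (methylcarbamoyl)amino and (methylcarbamoyl)oxy, so a position where a change truly shifts growth inhibition is yet to be shown.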